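A few compounds are considered here, and "the series" means these few. Any claim that something is new, unique, unknown or untested is made for them only; others in the source may bear on it.

Working notes on the series. Compound 1 `CC#CC(CC(=O)O)c1ccc(OCc2ccc3nc(-c4ccc(C5CCCCC5)cc4)cn3c2)cc1` gives 417 nM in an assay on isolated protein for agonist activity at Free fatty acid receptor 1 (Homo sapiens); a lower number here means that less compound is needed, a higher number that more compound is needed for the effect. Compound 2 `CC#CC(CC(=O)O)c1ccc(OCc2ccn3cc(-c4ccc(C)cc4C)nc3c2)cc1` gives 503 nM in this assay; the two numbers lie within the scatter of each other, so compound 1 is simply one of two comparable points. Compound 3 `CC#CC(CC(=O)O)c1ccc(OCc2ccc3nc(-c4ccccc4)cn3c2)cc1` has not been measured; it differs from compound 1 by hydrogen in place of cyclohexyl on an aromatic carbon. Among the measured compounds shown here, no measured pair shows this change, so the size of the step rests on expectation alone: a rise in the number, moderate, beyond the scatter. The step from compound 1 to compound 3 is expected to read a 3.1-fold higher number from compound 1 to compound 3 (0.49 log units; beyond the scatter). Compound 3 is therefore estimated at 1300 nM, with a range from 500 nM to 4000 nM.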

Compound 3, half-maximal effective concentration: 979 nM
Compound 3: middle estimate off by 1.3-fold (0.12 log units), on the high side; the range from low to high includes it.
By their numbers in this assay, from the lowest: compounds 1, 2 and 3 (each within the scatter of the next, the first and the last beyond it).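

In this assay, among the compounds shown here, hydrogen in place of cyclohexyl on this aromatic carbon gives the first one-place reading: a 2.3-fold higher number from compound 1 to compound 3 (0.37 log units; beyond the scatter) is a modest step beyond the scatter. The cyclohexyl group therefore lowers the number at this position, but compound 3, with a plain phenyl, still reads in the same assay without it. Nothing measured here accounts for the size of this step. As far as these compounds go, whether methyl, methoxy or tert-butyl on the same carbon would read nearer compound 1 or compound 3 stays open. A single pair also leaves open whether the step holds on other cores.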